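From 4-chlorophenyl to 3-bromophenyl on the shared core

The compounds below may be only part of what the source reports. "The series", "measured", "known", "first", "only" and "open" are said of these compounds alone.

In a toxicity assay on THP-1 cells (Homo sapiens) for inhibition (on this read-out lower numbers stand for higher toxicity in this test and higher numbers for lower toxicity in this test), compound 1 (`Cn1c(-c2ccccc2)cnc1NC(=O)c1ccc(Cl)cc1`) gives > 100000 nM as a limit of the assay and not a number. Compound 2 (`COc1ccc(-c2cnc(NC(=O)c3cc(-c4ccccn4)n[nH]3)n2C)cc1`) also stands at a limit, with >= 50000 nM as its entry. Within the data shown here, neither compound therefore has an exact reading, and no step between measured compounds is available. Compound 3 (`Cn1c(-c2ccccc2)cnc1NC(=O)c1cccc(Br)c1`) keeps the core of compound 1 and carries 3-bromophenyl in place of 4-chlorophenyl on a carbonyl carbon. Among the measured compounds shown here, since compound 1 has the limit > 100000 nM as its only reading, no change beyond the usual scatter is expected in this assay for this swap. The expected size of the step (a number no higher from compound 1 to compound 3 (the limit leaves the size open)) is an estimate only. In this assay compound 3 is estimated at 100000 nM within an expected range of 40000 nM to 200000 nM and is expected to stand at a limit too.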

Compound 3, half-maximal cytotoxic concentration: > 50000 nM
Compound 3: only a limit was reported; the forecaster's own chance of this, stated with the estimate: 85%; the middle value is on the limit's open side.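

In this assay, among these compounds, compound 1 and compound 3 both stand at limits of the assay and not at numbers, so no step between them can be read. The compounds shown leave open whether 3-bromophenyl and 4-chlorophenyl on the shared core differ at all in this assay.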